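The source may report more compounds than this note shows. Statements on the series, on what has been measured and on what is new or still open speak of the compounds shown alone.

Compound 1 `C=CC(=O)NCc1ccc(C(=O)Nc2ccc(C)c(Nc3nccc(-c4cccnc4)n3)c2)cc1` and compound 2 `C=CC(=O)NCc1ccc(C(=O)Nc2ccc(C)c(Nc3nccc(-c4cccnc4)n3)c2)cc1C(F)(F)F` share a core with compound 3 `C=CC(=O)Nc1cccc(C(=O)Nc2ccc(C)c(Nc3nccc(-c4cccnc4)n3)c2)c1`, and compound 4 `C=CC(=O)Nc1cc(C(=O)Nc2ccc(C)c(Nc3nccc(-c4cccnc4)n3)c2)cc(C(F)(F)F)c1` is the one not yet measured. In an ADME assay on BaF3 cells (Mus musculus) for cytotoxicity, read by CellTiter-Glo and CCK-8 assay, with a stated time of 72 h (on this read-out lower numbers stand for stronger inhibition of growth and higher numbers for weaker inhibition of growth), compound 1 gives only a limit of the assay, > 10000 nM. In this assay compound 2 likewise gives only a limit, > 10000 nM. In this assay, within the data shown here, compound 3 gives 2480 nM, the only number among the three. The change from compound 1 to compound 2 is trifluoromethyl in place of hydrogen on an aromatic carbon, and its step, a step that the two limits leave unreadable from compound 1 to compound 2, cannot be sized because of the limit of > 10000 nM in this assay, at which 2 of the 3 values shown sit. The same kind of change leads from compound 3 to compound 4, (trifluoromethyl in place of hydrogen on an aromatic carbon), though the surroundings differ: in compound 2 the group is ortho to a ((vinylcarbonyl)amino)methyl group, in compound 4 meta to a (vinylcarbonyl)amino group. The difference between the core of compound 1 and the core of compound 3 is not broken down here. Since the earlier step is unreadable, he expects the step in this assay from compound 3 to compound 4 to be small, a 1.0-fold higher number from compound 3 to compound 4 (0.00 log units; within the scatter), resting on the value of compound 3, 2480 nM. He estimates compound 4 at 2500 nM, between 700 nM and 9000 nM.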

Compound 4, concentration for 50% growth inhibition: 5460 nM
For compound 4 the middle estimate is 2.2-fold (0.34 log units) below the measured one, and the stated range covers the measured number.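

In this assay the change shows a 2.2-fold higher number from compound 3 to compound 4 (0.34 log units; beyond the scatter), so on this core trifluoromethyl meta to a (vinylcarbonyl)amino group goes with weaker inhibition of growth. The same change on the core of compound 1 cannot be read, because neither compound of that pair gives a number, only a limit of the assay: the limit of > 10000 nM in this assay, at which 2 of the 4 values shown sit. The series therefore offers one readable size for this change, on one core, and it does not show whether that size carries over from one core to the other, nor what lies behind it.

The compounds shown leave open whether the weaker inhibition belongs to trifluoromethyl itself or would also appear with another group at the same place on the core of compound 3, such as a methyl, a nitrile or a dimethylamino group. They also leave open how a basic amine such as a piperazine or a carboxylic acid would fare there.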